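A few compounds are considered here, and "the series" means these few. Any claim that something is new, unique, unknown or untested is made for them only; others in the source may bear on it.

Three compounds of this series have numbers in an assay on isolated protein for inhibition of Amine oxidase [flavin-containing] A (Homo sapiens), read by fluorescence; on this read-out higher numbers stand for weaker inhibition and lower numbers for stronger inhibition: compound 1 `CCC(CC)=NNc1nc(-c2cccc(OC)c2)cs1` gives 824 nM, compound 3 `COc1cccc(-c2csc(N/N=C3\CCC(C)C3)n2)c1` gives 1450 nM, and compound 2 `COc1cccc(-c2csc(N/N=C(\C)c3ccncc3)n2)c1` gives 3710 nM, the highest of the three and beyond the scatter from both others. For the measured compounds named here, the single measured step, a 1.8-fold higher number from compound 1 to compound 3 (0.25 log units; within the scatter), exchanges one group on a nitrogen on an aromatic ring for another and stays within the scatter. Compound 4 `CCCCCC/C(C)=N/Nc1nc(-c2cccc(OC)c2)cs1` arises from compound 2 by hexyl in place of pyridin-4-yl on a carbon with a double bond to nitrogen. Going by the values given here, no step covers such an exchange directly; only the gap between compound 2 and compounds 1 and 3, neither of which carries an aromatic group at that position, bears on it. A move toward the number of compound 1 is expected. The step of a 3.7-fold lower number from compound 2 to compound 4 (0.57 log units; beyond the scatter) is the expected size. For compound 4 in this assay the expected value is 1000 nM, within 400 nM to 2600 nM.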

Compound 4, half-maximal inhibitory concentration: 1380 nM
Beside the measured number, compound 4's estimate is 1.4-fold (0.14 log units) below it; low and high end bracket the measured number.
By their numbers in this assay, from the lowest: compounds 1, 4 and 3 (each within the scatter of the next); then compound 2.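

In this assay hexyl in place of pyridin-4-yl gives a 2.7-fold lower number from compound 2 to compound 4 (0.43 log units; beyond the scatter) on a carbon with a double bond to nitrogen. This position therefore takes an open chain without a ring, and pyridin-4-yl is not required for the number at this place. Nothing at hand gives a reason for this step.

Going by these compounds, whether the step comes from adding hexyl or from losing pyridin-4-yl remains open. A phenyl, a butyl chain or a hexyl chain ending in an amine at this place could separate the two.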